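Amino for hydroxymethyl on the thiazole-like core: compound 4

The compounds below may be only part of what the source reports. "The series", "measured", "known", "first", "only" and "open" are said of these compounds alone.

Measured compounds:
compound 1 `CCNC(=O)c1sc(-c2ccccc2)nc1O`: > 100000 nM
compound 2 `CCOC(=O)c1sc(-c2ccccc2)nc1CO`: > 100000 nM
compound 3 `O=C(c1sc(-c2ccccc2O)nc1O)N1CCCCO1`: 81 nM

In an assay on HEK293 cells for inhibition of transient receptor potential cation channel subfamily M member 8 (Homo sapiens), read by FLIPR, with stated times of 5 min and 3 min (on this read-out higher numbers stand for weaker inhibition and lower numbers for stronger inhibition), compound 2 gives > 100000 nM, which is a limit of the assay and not a number. Compound 1 also gives a limit in this assay, > 100000 nM. Compound 3, which carries a different amide and a hydroxy on the phenyl, gives 81 nM in this assay. Compound 2 therefore stands at the limit of > 100000 nM in this assay, at which 2 of the 3 values shown sit, with no number to place it among the others.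

The step to compound 4 `CCOC(=O)c1sc(-c2ccccc2)nc1N` is amino in place of hydroxymethyl on an aromatic carbon; in words, amino in place of hydroxymethyl on an aromatic carbon, next to the ring nitrogen and next to the ring atom that bears the ethoxycarbonyl group, with the ethyl ester and the phenyl left as they are.

Within the data shown here, no measured pair differs in one place, so no step size is known. Since compound 2 sits at a limit, the change cannot be read as gaining or losing beyond the scatter from any shown pair. The expectation for compound 4 is that it stays close to where compound 2 sits, with the step of a number no higher from compound 2 to compound 4 (the limit leaves the size open) estimated as none beyond the scatter. Compound 4 is estimated at 100000 nM in this assay, within 20000 nM to 500000 nM, most likely reported again as a limit.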

Compound 4, half-maximal inhibitory concentration: > 100000 nM
Compound 4: no number, only a limit; the forecaster's own chance of this, stated with the estimate: 70%; the middle value lies on the limit itself.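

In this assay compound 4 gives > 100000 nM, a limit of the assay and not a number, and compound 2 sits at the same kind of limit, so no step can be read between compound 2 and compound 4. The compounds shown leave open how amino and hydroxymethyl compare in their effect on inhibition.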